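The source may hold more compounds than are shown below. What is called first, only, known or untested is meant among the compounds shown, and "the series" means these compounds.

Measured so far:
compound 1 `CC(c1cccc(NS(C)(=O)=O)c1)c1c[nH]cn1`: 92%
compound 2 `CC(=O)Nc1cccc2c1CCCC2c1c[nH]cn1`: 70%

For the measured compounds named here, in a functional assay on Urethra with Alpha-1A adrenergic receptor (Oryctolagus cuniculus) as the target (a higher number here means a larger maximal response, a lower number a smaller maximal response), compound 2 gives 70%, the lower of the two numbers so far. Compound 1 gives 92%, a gap that lies beyond the usual scatter of such measurements. Compound 3 `CN(c1cccc2c1CCCC2c1c[nH]cn1)S(C)(=O)=O` has not been measured yet. It differs from compound 2 by methyl(methylsulfonyl)amino in place of acetamido on an aromatic carbon. Going by the values given here, no measured pair shows this same change on this core, so its effect is open: a rise, a fall, or nothing beyond the scatter are all possible. Compound 3 is estimated at 75%, between 55% and 95%. The expected step is a number 5 percentage points higher from compound 2 to compound 3 (within the scatter).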

Compound 3, largest response reached (reported as efficacy), in percent of the reference or control that the assay uses: 79%
For compound 3 the middle estimate is 4 percentage points below the measured one; measured number inside the range.
By their numbers in this assay, from the lowest: compounds 2 and 3 (each within the scatter of the next); then compound 1.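

In this assay, placing methyl(methylsulfonyl)amino instead of acetamido on this aromatic carbon gives a number 9 percentage points higher from compound 2 to compound 3 (within the scatter). This single pair therefore shows that, on this core, maximal response does not separate the two groups, even though the entering group has no hydrogen-bond donors and the leaving group has one. No measurement here gives a reason for this result.

On these data alone, whether an amine, a carboxylic acid or a longer chain on the same carbon would behave alike remains open. So does the effect of this swap on any other core.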